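A Methyl on the Phenol Oxygen: From Compound 2 to Compound 3

The source may hold more compounds than are shown below. What is called first, only, known or untested is meant among the compounds shown, and "the series" means these compounds.

Of the compounds shown here, two have been tested in a functional assay on SH-SY5Y cells (Homo sapiens) for cytotoxicity, read by MTT assay, with stated times of 8 h, 30 min and 12 h, tested at 0.5 uM; on this read-out higher numbers stand for a stronger effect at the one concentration tested and lower numbers for a weaker effect. Compound 1 `COc1ccc(CNC(=N)[C@@H]2CCC(=O)N2Cc2ccccc2)cc1` gives 23.6%. Compound 2 `COc1ccc(CN2C(=O)CC[C@H]2C(=N)NCc2ccc(O)cc2)cc1` gives 20.5%, the lower of the two numbers, though the gap to compound 1 lies within the usual scatter, so the two cannot be told apart. Compound 3 `COc1ccc(CNC(=N)[C@@H]2CCC(=O)N2Cc2ccc(OC)cc2)cc1` has not yet been measured. It differs from compound 2 in one place (methyl in place of hydrogen on an oxygen on an aromatic ring), which turns the 4-hydroxybenzyl group into a 4-methoxybenzyl group. Going by the values given here, no step between measured compounds is known that isolates this change, so its size can only be guessed. The step of a number 1.5 percentage points higher from compound 2 to compound 3 (within the scatter) is expected to be small, with no clear direction, and to stay within the scatter. Because compound 2 gives 20.5% and compound 1 gives 23.6%, compound 3 is expected to reach about 22%, in a range from 12% to 33%.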

Compound 3, a percentage reported as activity, at one concentration (the size of the read-out at that concentration, not a potency): 24.8%
Estimate against measurement, compound 3: 2.8 percentage points below; the range from low to high includes it.
By their numbers in this assay, from the lowest: compounds 2, 1 and 3 (each within the scatter of the next).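

In this assay, methyl in place of hydrogen on the oxygen on the aromatic ring gives a number 4.3 percentage points higher from compound 2 to compound 3 (within the scatter) and so, at this one site, 4-hydroxybenzyl and 4-methoxybenzyl cannot be told apart. The step from a hydrogen to a methoxy on an aromatic carbon, which gives a number 1.2 percentage points higher from compound 1 to compound 3 (within the scatter) as the second single-place comparison, likewise leaves the two compounds indistinguishable, so neither change on this benzyl group shows a measurable effect on the read-out. Nothing available explains these results or tells what the oxygen or its methyl does here. From the compounds shown here alone, whether a larger change at this site, such as an ethoxy group, a longer chain on the oxygen, an amine or a carboxylic acid, would move the number beyond the scatter remains open. Going by these compounds, the read-out also comes from a single concentration, so whether the effect would be stronger or weaker at any other concentration remains open too.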